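Trifluoromethyl to Methylsulfanyl: Expected Clearance of Compound 4

The source may report more compounds than this note shows. Statements on the series, on what has been measured and on what is new or still open speak of the compounds shown alone.

Measured in an in vitro ADME assay on microsomes from liver (Mus musculus) for metabolic stability; on this read-out lower numbers stand for slow clearance and higher numbers for fast clearance:
Compound 1 `Cc1cc(Nc2ccc(S(F)(F)(F)(F)F)cc2)n2nc(C(F)(F)F)nc2n1`: < 6 mL.min-1.g-1, a limit of the assay
Compound 2 `Cc1cc(Nc2ccc(Cl)cc2)n2nc(C(C)C)nc2n1`: 158 mL.min-1.g-1
Compound 3 `CCOc1nc2nc(C)cc(Nc3ccc(C(F)(F)F)cc3)n2n1`: 14.4 mL.min-1.g-1

Compound 1 stands at the limit of < 6 mL.min-1.g-1 in this assay, at which 1 of the 3 values shown sits, so only a limit and no number is known for it in this assay. Compound 2 gives 158 mL.min-1.g-1 and compound 3 gives 14.4 mL.min-1.g-1, both of them numbers. Both of these numbers lie higher than where compound 1 stands.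

Compound 4 `CSc1nc2nc(C)cc(Nc3ccc(S(F)(F)(F)(F)F)cc3)n2n1` differs from compound 1 in one place: methylsulfanyl in place of trifluoromethyl on an aromatic carbon. Going by the values given here, no measured pair shows this same change, so the step can only be expected, not read off. The step from compound 1 to compound 4 in this assay is expected to be an at least 4.1-fold higher number from compound 1 to compound 4 (0.61 log units; beyond the scatter), in the direction of faster clearance. Compound 4 is estimated at 25 mL.min-1.g-1, with a range from 8 mL.min-1.g-1 to 80 mL.min-1.g-1.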

Compound 4, intrinsic clearance in microsomes: 108 mL.min-1.g-1
Compound 4: middle estimate off by 4.3-fold (0.64 log units), on the low side; measured number outside the range, above it.
By their numbers in this assay, from the lowest: compound 3; then compounds 4 and 2 (each within the scatter of the next). At a limit, below all of these: compound 1.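

In this assay, methylsulfanyl in place of trifluoromethyl on this aromatic carbon, between two ring nitrogen atoms, gives an at least 18-fold higher number from compound 1 to compound 4 (1.25 log units; beyond the scatter). Going by these compounds alone, this large step is the first reading of a single change at this place, with the rest of the molecule held the same. Compound 1 stands at a limit of the assay and not at a number, so the full size of the step stays unknown: the limit of < 6 mL.min-1.g-1 in this assay, at which 1 of the 4 values shown sits.

The compounds shown leave open whether an amine or a methoxy group at this place would give a step of similar size. They also leave open whether the same change would give a step of this size on a different core.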